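Benzyl to anilino on compound 1

The source may hold more compounds than are shown below. What is called first, only, known or untested is meant among the compounds shown, and "the series" means these compounds.

Measured in an ADME assay on microsomes from liver (Canis lupus familiaris) for metabolic stability, read by LC-MS, using NADPH, with a stated time of 30 min, tested at 1 uM (a higher number here means that more of the compound is left, a lower number that less of the compound is left), so far
Compound 1 `O=C(Oc1ccc(OCc2ccccc2)cc1)N(Cc1ccccc1)S(=O)(=O)c1ccc(Cl)cc1` with 37.7%
Compound 2 `O=C(Nc1ccc(OCCCCc2ccccc2)cc1)N(Cc1ccccc1)S(=O)(=O)c1ccc(Cl)cc1` with 86.4%

Compound 1 with 37.7% is the lower of the two numbers in this assay and its gap to compound 2 lies beyond the scatter. These two compounds differ in more than one place, so neither gives a direct reading of the change considered next. Compound 3 `O=C(Oc1ccc(OCc2ccccc2)cc1)N(Nc1ccccc1)S(=O)(=O)c1ccc(Cl)cc1` keeps the core of compound 1 but has anilino in place of benzyl on an amide-type nitrogen. Going by the values given here, no measured pair shows this exchange, so no step beyond the scatter is expected in this assay in either direction, and that expectation remains uncertain. The expected change is a number 4.3 percentage points higher from compound 1 to compound 3 (within the scatter) in this estimate. For compound 3 the estimated value is 42% with an expected range from 20% to 68% on repeated measurement.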

Compound 3, percent of the compound remaining: 48.5%
For compound 3 the middle estimate is 6.5 percentage points below the measured one, within the range that was stated.
By their numbers in this assay, from the lowest: compound 1; then compound 3; then compound 2.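

In this assay, going by these compounds alone, anilino in place of benzyl on the amide-type nitrogen, whose other neighbours are the carbonyl carbon and the sulfonyl sulfur, gives the first direct reading of this position: a number 10.8 percentage points higher from compound 1 to compound 3 (beyond the scatter). The step shows that this place responds to an exchange that leaves the count of heavy atoms and the six-membered aromatic ring unchanged, while the entering group brings a nitrogen with a hydrogen-bond donor and acceptor. Nothing at hand says why the number moves.

The compounds shown leave open whether a phenethyl chain or a methylamino group at this place would read differently from anilino. They also leave open whether the same exchange would give a similar step on the core of compound 2, which carries benzyl at this place too.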